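The compounds below may be only part of what the source reports. "The series", "measured", "known", "first", "only" and "open" are said of these compounds alone.

Of the compounds shown here, three that share one core have been measured in a physicochemical assay for lipophilicity, at pH 7.4; a lower number here means a more polar compound, a higher number a more lipophilic compound. Compound 1 `Cc1cc(C(=O)Nc2ccccc2)nn1Cc1cc(Cl)ccc1OCc1ccccc1`, with a phenylcarbamoyl group, reports > 3.7, which is a limit and not a number. Compound 2 `Cc1cc(NC(=O)C(C)C)nn1Cc1cc(Cl)ccc1OCc1ccccc1`, with an (isopropylcarbonyl)amino group, reports > 3.7, also a limit. Within the data shown here, compound 3 `Cc1cc(NC(=O)OCC(C)C)nn1Cc1cc(Cl)ccc1OCc1ccccc1`, with an (isobutoxycarbonyl)amino group, gives 3.3, the only true number in the set. The other two compounds stand at the limit of > 3.7 in this assay, at which 2 of the 3 values shown sit.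

The next compound is compound 4 `COC(=O)Nc1cc(C)n(Cc2cc(Cl)ccc2OCc2ccccc2)n1`. The change is hydrogen in place of isopropyl on a saturated chain carbon bound to an oxygen next to a carbonyl group, so isobutoxy becomes methoxy.

Two measured steps offer some guidance: a number at least 0.40 log units lower from compound 1 to compound 3 (beyond the scatter) and a number at least 0.40 log units lower from compound 2 to compound 3 (beyond the scatter). A third, a step that the two limits leave unreadable from compound 1 to compound 2, gives no size. The first two are bounds rather than exact sizes, and neither shortens the isobutoxy chain, so they guide only loosely. Starting from compound 3 at 3.3, the shorter methoxy chain leads to an expected fall beyond the scatter. The expected change in this assay is a number 0.80 log units lower from compound 3 to compound 4 (beyond the scatter). For compound 4 the estimated value is 2.5, with an expected range from 2 to 3.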

Compound 4, distribution coefficient: > 3.7
Compound 4: a limit, no number (the forecaster's own chance of this, stated with the estimate: 3%); middle value at least 1.20 log units away from the limit.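

In this assay compound 4, with methoxy in place of isobutoxy, reports > 3.7, which is a limit and not a number. Shortening the chain at this place gives a number at least 0.40 log units higher from compound 3 to compound 4 (beyond the scatter) and does not give the fall a shorter chain might suggest, so among these two compounds the lower reading belongs to isobutoxy and is not shared by methoxy on the same carbonyl carbon. The steps from compound 1 and from compound 2 to compound 4 cannot be read, and the set now leans heavily on a single ceiling: the limit of > 3.7 in this assay, at which 3 of the 4 values shown sit.

Going by these compounds, how far compound 4 really lies past its limit stays open, so the step from compound 3 has a lower bound on its size but no true size. Also open, on these data alone, is where ethoxy, a longer chain such as hexyloxy, or a chain ending in an amine would fall on this carbonyl carbon, and whether any of them would give a true number that could show how reading and chain length relate.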